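Chloro for Methoxy: One Change, One Expected Outcome

The source may hold more compounds than are shown below. What is called first, only, known or untested is meant among the compounds shown, and "the series" means these compounds.

Measured so far:
compound 1, `CCSC(=S)SCC(=O)c1ccc(S(=O)(=O)Nc2ccc(OC)cc2)cc1`: 4320 nM
compound 2, `CCOC(=S)SCC(=O)c1ccc(OC)cc1`: 4640 nM

Of the compounds shown here, two have been measured in a functional assay on HeLa cells (Homo sapiens) for cytotoxicity, read by resazurin assay, with a stated time of 72 h; a lower number here means a stronger inhibitor, a higher number a weaker inhibitor. Compound 1 `CCSC(=S)SCC(=O)c1ccc(S(=O)(=O)Nc2ccc(OC)cc2)cc1` gives 4320 nM, and compound 2 `CCOC(=S)SCC(=O)c1ccc(OC)cc1` gives 4640 nM. These two numbers sit within the usual scatter of repeated measurements of each other, so neither compound can be called stronger or weaker than the other; compound 1 holds one of two numbers that are, for practical purposes, the same. Compound 1 and compound 2 also differ from each other in several places at once, so nothing about any single change can be read from that pair.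

Compound 3 `CCSC(=S)SCC(=O)c1ccc(S(=O)(=O)Nc2ccc(Cl)cc2)cc1` has not yet been measured. It differs from compound 1 in one place: chloro in place of methoxy on an aromatic carbon. Among the measured compounds shown here, no measured pair in this set isolates a change of this kind, so there is no direct precedent. For the measured compounds named here, with only two close numbers to go on, the most defensible expectation is a step of modest size in this assay, in either direction, and quite possibly none beyond the scatter. Compound 3 is therefore expected to give about 3500 nM (range 1400 nM to 9000 nM), which corresponds to an expected step of a 1.2-fold lower number from compound 1 to compound 3 (0.09 log units; within the scatter).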

Compound 3, half-maximal inhibitory concentration: 6080 nM
Compound 3: middle estimate off by 1.7-fold (0.24 log units), on the low side; the measured number falls inside the stated range.
By their numbers in this assay, from the lowest: compounds 1, 2 and 3 (each within the scatter of the next).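

Among the compounds shown here, this is the first pair in the set that differs in one place only, so a single change can now be read: in this assay, chloro in place of methoxy on an aromatic carbon gives a 1.4-fold higher number from compound 1 to compound 3 (0.15 log units; within the scatter). Going from 4-methoxyphenyl to 4-chlorophenyl therefore leaves the cytotoxicity of compound 3 indistinguishable from that of compound 1, which shows that the methoxy group, with its oxygen and its hydrogen-bond acceptor, is not required at this position to keep that level of activity. Nothing available here explains why the two groups read alike, so the result stands as an observation only.

The compounds shown leave open how far this position accepts other groups: an amine, a carboxylic acid or a longer chain such as ethoxy on the same aromatic carbon could give a clearly different number from the two groups compared here. Whether the same swap would read alike on the 4-methoxyphenyl group of compound 2, which sits on a different core, also remains an open question.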